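Oxamic acid series: from methyl to hydroxymethyl

The compounds below may be only part of what the source reports. "The series", "measured", "known", "first", "only" and "open" are said of these compounds alone.

Measured in a functional assay on the whole organism with Rattus norvegicus as the target; on this read-out lower numbers stand for an effect already at smaller amounts and higher numbers for an effect only at larger amounts of compound:
- compound 1 `CCOCCOC(=O)C(=O)Nc1nc(-c2cc(C)on2)cs1`: 1.3 mg/kg
- compound 2 `Cc1cc(-c2csc(NC(=O)C(=O)O)n2)on1`: 0.3 mg/kg
- compound 3 `Cc1cc(-c2csc(NC(=O)C(=O)O)n2)no1`: 1.7 mg/kg

Compound 3, at 1.7 mg/kg, lies within the scatter of compound 1, at 1.3 mg/kg. Compound 2, at 0.3 mg/kg, shows a lower number than compound 3, and that gap lies beyond the scatter.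

The next compound is compound 4 `O=C(O)C(=O)Nc1nc(-c2cc(CO)on2)cs1`. Its difference from compound 3 is hydroxy in place of hydrogen on a saturated chain carbon bound to an aromatic carbon, which reads as methyl to hydroxymethyl.

For the measured compounds named here, the only measured step is a 1.3-fold higher number from compound 1 to compound 3 (0.12 log units; within the scatter). It concerns hydrogen in place of 2-ethoxyethyl on an oxygen next to a carbonyl group, so it bears on the present change only indirectly. No measured step covers a change at the methyl itself, and the range must stay wide for that reason. With nothing pointing either way, no step beyond the scatter is expected in this assay. The estimate amounts to a 1.2-fold higher number from compound 3 to compound 4 (0.07 log units; within the scatter), a small expected move. Compound 4 is expected at 2 mg/kg, within an estimated range of 0.6 mg/kg to 7 mg/kg.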

Compound 4, dose for half-maximal effect: > 100 mg/kg
Compound 4 gave a limit, no number; the forecaster's own chance of this, stated with the estimate: 5%; middle value at least 50-fold (1.69 log units) from the limit.
By their numbers in this assay, from the lowest: compound 2; then compounds 1 and 3 (each within the scatter of the next). At a limit, above all of these: compound 4.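

For the compounds shown here, the place on a saturated chain carbon bound to an aromatic carbon proves far from indifferent in this assay: methyl to hydroxymethyl gives an at least 58-fold higher number from compound 3 to compound 4 (1.76 log units; beyond the scatter), whereas the only earlier step, hydrogen in place of 2-ethoxyethyl, is a 1.3-fold higher number from compound 1 to compound 3 (0.12 log units; within the scatter). Compound 4 gives > 100 mg/kg, which is a limit of the assay and not a number. A change of one heavy atom therefore ends in a limit rather than a number, and this reading rests on a single value: the limit of > 100 mg/kg in this assay, at which 1 of the 4 values shown sits.

The compounds shown hold no methoxymethyl, aminomethyl or ethyl at this place, so it stays open whether the hydroxy itself matters or almost any change to the methyl would give the same result. Also open, going by these compounds, is whether hydroxymethyl would give a similar result on the 2-ethoxyethyl ester of compound 1 or on the core of compound 2.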